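The compounds below may be only part of what the source reports. "The series", "measured", "known", "first", "only" and "open" are said of these compounds alone.

Measured compounds:
Compound 1, `CCCCCCCCCCn1cc(-c2nc3ccccc3cc2CCCCC)nn1`, gives > 100 ug/mL in a functional assay on COLO 205 cells (Homo sapiens) for cytotoxicity, read by MTT assay, with a stated time of 24 h; on this read-out higher numbers stand for weaker inhibition and lower numbers for stronger inhibition; this is a limit of the assay, not a number.
Compound 2, `CCCCCc1cc2ccccc2nc1-c1cn(-c2ccc(F)cc2)nn1`, gives > 100 ug/mL, again a limit.
Compound 3, `CCCc1cc2ccccc2nc1-c1cn(CCC(F)(F)C(F)(F)C(F)(F)C(F)(F)C(F)(F)C(F)(F)C(F)(F)C(F)(F)F)nn1`, gives > 100 ug/mL, also a limit.

Compound 1 therefore stands only at a limit, and so do the two other measured compounds, which is what the limit of > 100 ug/mL in this assay, at which 3 of the 3 values shown sit, records. For the measured compounds named here, the one measured step, a step that the two limits leave unreadable from compound 1 to compound 2, cannot be read because both ends are limits, so it gives no guide to size or direction.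

Compound 4, `CCCCCCCCCCn1cc(-c2nc3ccccc3cc2C)nn1`, differs from compound 1 by hydrogen in place of butyl on a saturated chain carbon bound to an aromatic carbon. Going by the values given here, no measured step bears on this change; the only evidence is that compound 1 and its two companions all sit at the limit, so there is no sign that a smaller group on that carbon would bring a readable number. The step from compound 1 to compound 4 is expected to be a step that the limit leaves unreadable from compound 1 to compound 4, meaning no change beyond the scatter that can be seen. Compound 4 is accordingly expected to give about 150 ug/mL, in the range 60 ug/mL to 400 ug/mL, most likely again reported only as a limit.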

Compound 4, half-maximal inhibitory concentration: 44.5 ug/mL
Estimate against measurement, compound 4: 3.4-fold (0.53 log units) above, outside the stated range (below it).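

Compound 4 is the first compound shown to give a readable number in this assay, which shows that this carbon is a place where a change can move the read-out. Going from pentyl to methyl gives an at least 2.2-fold lower number from compound 1 to compound 4 (0.35 log units; beyond the scatter), and a lower number here stands for stronger inhibition, whereas the earlier compounds showed only that nothing could be read. The size of this step remains a lower bound, because one end of it is a limit: the limit of > 100 ug/mL in this assay, at which 3 of the 4 values shown sit.

The compounds shown leave open what an ethyl chain, an amine or a carboxylic acid would do in place of the methyl of compound 4. They also leave open whether the decyl on the aromatic nitrogen still matters once methyl is present, for example whether a 4-fluorophenyl there would keep a readable number.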